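A Methyl on a Phenolic Oxygen: Expected Cytotoxicity

The source may hold more compounds than are shown below. What is called first, only, known or untested is meant among the compounds shown, and "the series" means these compounds.

Compound 1 `COC(=O)c1c(-c2ccc(OC)cc2)oc2ccccc2c1=O` and compound 2 `COC(=O)c1c(-c2ccc(O)cc2)oc2ccccc2c1=O` share one core and differ by methyl in place of hydrogen on an oxygen on an aromatic ring. In a functional assay on HT-29 cells (Homo sapiens) for cytotoxicity, read by MTT assay, with a stated time of 6 days (on this read-out higher numbers stand for an effect only at larger amounts of compound and lower numbers for an effect already at smaller amounts), compound 1 gives > 25 ug/mL, which is a limit of the assay and not a number. In this assay compound 2 gives > 25 ug/mL, likewise a limit. The step is a step that the two limits leave unreadable from compound 2 to compound 1 because both values sit at the limit of > 25 ug/mL in this assay, at which 2 of the 3 values shown sit. Compound 3 `COc1cc(-c2cc(=O)c3cc(O)ccc3o2)cc(OC)c1OC` has a core whose difference from that of compound 2 is not broken down here; in this assay compound 3 gives 7.85 ug/mL. Compound 4 `COc1ccc2oc(-c3cc(OC)c(OC)c(OC)c3)cc(=O)c2c1` differs from compound 3 by methyl in place of hydrogen on an oxygen on an aromatic ring, the same change, at a place described in the same words. With the measured step unreadable, the expectation for compound 4 rests on compound 3 and its 7.85 ug/mL alone, and the expected step is a 1.3-fold higher number from compound 3 to compound 4 (0.11 log units; within the scatter), within scatter. Compound 4 is thus expected to give 10 ug/mL, between 3.5 ug/mL and 25 ug/mL.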

Compound 4, concentration for half-maximal effect: > 25 ug/mL
Compound 4: no number, only a limit (the forecaster's own chance of this, stated with the estimate: 25%); at least 2.5-fold (0.39 log units) between middle value and limit.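

On the core of compound 3, methyl in place of hydrogen on an oxygen on an aromatic ring gives an at least 3.1-fold higher number from compound 3 to compound 4 (0.50 log units; beyond the scatter) in this assay. Compound 4 gives > 25 ug/mL, which is a limit of the assay and not a number, so the step has only a lower bound and no exact size. The step from compound 2 to compound 1 cannot be read, so the shown data do not tell whether the change has the same effect on both cores: the limit of > 25 ug/mL in this assay, at which 3 of the 4 values shown sit.

Within the data shown here, compound 3 gives 7.85 ug/mL, the only number in this set. The compounds shown leave open how a longer chain on that oxygen, or an amine or a carboxylic acid in place of hydroxy, would read on this core.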